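Adding a Methoxyphenyl Where Compound 3 Carries a Methyl

A few compounds are considered here, and "the series" means these few. Any claim that something is new, unique, unknown or untested is made for them only; others in the source may bear on it.

Measured in an ADME assay on J774.A1 cells (Mus musculus) for cytotoxicity, read by MTT assay, with a stated time of 72 h; a higher number here means that more compound is tolerated, a lower number that less compound is tolerated:
Compound 1 `N/C(=N/O)c1ccc(C2=C(S(=O)(=O)c3ccc(F)cc3)CC(c3ccccc3)(c3ccccc3)O2)cc1` gives 10200 nM.
Compound 2 `CC1(c2ccc(-c3ccc(/C(N)=N\O)cc3)cc2)CC(S(=O)(=O)c2ccc(F)cc2)=C(c2ccc(/C(N)=N\O)cc2)O1` gives 3940 nM.
Compound 3 `CC1(c2ccccc2)CC(S(=O)(=O)c2ccc(F)cc2)=C(c2ccc(/C(N)=N\O)cc2)O1` gives 29700 nM.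

Compound 3 has the highest number of the three. Compound 4 `COc1ccc(C2(c3ccccc3)CC(S(=O)(=O)c3ccc(F)cc3)=C(c3ccc(/C(N)=N\O)cc3)O2)cc1` differs from it by 4-methoxyphenyl in place of methyl on a saturated ring carbon. For the measured compounds named here, one measured step bears directly on this: a 2.9-fold higher number from compound 1 to compound 3 (0.46 log units; beyond the scatter), the removal of a phenyl from that same saturated ring carbon. The change to compound 4 runs the other way, adding an aromatic ring at that carbon, so a step of similar size downward in this assay is expected. The step of a 7.5-fold higher number from compound 2 to compound 3 (0.88 log units; beyond the scatter) removed a large group on an aromatic carbon and is a weaker guide. Compound 4 is therefore expected to give a lower number than compound 3, estimated at 11000 nM with a range of 4000 nM to 30000 nM, a step of a 2.7-fold lower number from compound 3 to compound 4 (0.43 log units; beyond the scatter).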

Compound 4, half-maximal cytotoxic concentration: 11300 nM
Compound 4: middle estimate off by 1.0-fold (0.01 log units), on the low side; measured number inside the range.
By their numbers in this assay, from the lowest: compound 2; then compounds 1 and 4 (each within the scatter of the next); then compound 3.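

In this assay, the drop seen with phenyl at this saturated ring carbon in compound 1 returns with 4-methoxyphenyl in place of methyl, as a 2.6-fold lower number from compound 3 to compound 4 (0.42 log units; beyond the scatter) shows. The methoxy itself adds nothing that can be told apart, since a 1.1-fold higher number from compound 1 to compound 4 (0.04 log units; within the scatter) stays inside the usual scatter. Nothing available here explains these numbers.

From the compounds shown here alone, whether an amine or a carboxylic acid in place of the methoxy would also leave the number unmoved stays open. So does what an ethyl at the saturated ring carbon would give.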